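A few compounds are considered here, and "the series" means these few. Any claim that something is new, unique, unknown or untested is made for them only; others in the source may bear on it.

Measured so far in a functional assay on CFPAC-1 cells (Homo sapiens) for antiproliferative activity, read by MTT assay, with a stated time of 72 h; on this read-out lower numbers stand for stronger inhibition and higher numbers for weaker inhibition:
- compound 1 `O=C1O[C@H]([C@@H](O)Cn2cc(-c3cc(C(F)(F)F)cc(C(F)(F)F)c3)nn2)C(OCc2ccccc2)=C1OCc1ccccc1`, with 66500 nM
- compound 2 `CCCCc1cn(C[C@H](O)[C@H]2OC(=O)C(OCc3ccccc3)=C2OCc2ccccc2)nn1`, with 73200 nM
- compound 3 `COc1ccc(-c2cn(C/C=C3\OC(=O)C(OCc4ccccc4)=C3OCc3ccccc3)nn2)cc1`, with > 100000 nM, which is a limit of the assay and not a number

Of the two actual numbers, compound 2 holds the higher one, but compound 1 is its nearest neighbour and the gap between them lies within the usual scatter of repeated measurements, so the two cannot be told apart. For compound 3 only a limit is known (the limit of > 100000 nM in this assay, at which 1 of the 3 values shown sits). All three share the same core, differing in what hangs on the triazole and in the short linker to it.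

Compound 4 `Cc1ccc(-c2cn(C[C@H](O)[C@H]3OC(=O)C(OCc4ccccc4)=C3OCc3ccccc3)nn2)cc1` has not yet been measured. It differs from compound 2 in one place: 4-methylphenyl in place of butyl on an aromatic carbon. For the measured compounds named here, no measured pair differs in exactly this way, so the size of the step cannot be read off directly. Compound 1 also carries an aromatic ring on the triazole and gives 66500 nM, which sits within scatter of compound 2, so a step that stays within the scatter, or a modest drift toward weaker inhibition, is expected from compound 2 to compound 4, that is a 1.1-fold higher number from compound 2 to compound 4 (0.04 log units; within the scatter). Compound 4 is therefore estimated at 80000 nM, expected between 35000 nM and 180000 nM.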

Compound 4, half-maximal inhibitory concentration: > 100000 nM
Compound 4 gave a limit, no number; the forecaster's own chance of this, stated with the estimate: 30%; middle value at least 1.2-fold (0.09 log units) away from the limit.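

For the compounds shown here, replacing butyl with 4-methylphenyl on this aromatic carbon of the triazole gives the first step that can be read at this position in this assay: an at least 1.3-fold higher number from compound 2 to compound 4 (0.13 log units; that floor lies within the scatter). An aromatic ring at this position does not on its own decide the result, as compound 1 also carries one there and still gives a real number, 66500 nM. Compound 4 gives a limit and not a number, and it is the same limit that compound 3 gives: the limit of > 100000 nM in this assay, at which 2 of the 4 values shown sit.

Since only a floor is known for this step, and that floor lies within the scatter, the compounds shown cannot settle whether the change truly weakens inhibition or by how much. Also open, on these data alone, is how this carbon of the triazole would respond to other groups, such as an unsubstituted phenyl, a longer chain like octyl, a primary amine or a carboxylic acid, and whether any of them would bring the read-out clearly below the values seen so far.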